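Amide replacement on the pyrazole core, lipophilicity at the limit

This account rests on a few compounds, and the source may have more. Where it says the series, first, only, none or still open, it means among the compounds named here.

Compound 1 `Cc1cc(C(=O)Nc2ccccc2)nn1Cc1cc(Cl)ccc1OCc1ccccc1` is the reference. In a physicochemical assay for lipophilicity, at pH 7.4 (on this read-out higher numbers stand for higher lipophilicity and lower numbers for lower lipophilicity), compound 1 gives > 3.7, which is a limit of the assay and not a number. Compound 2 `Cc1cc(C(=O)NCc2ccccc2)nn1Cc1cc(Cl)ccc1OCc1ccccc1` and compound 3 `Cc1cc(NC(=O)C(C)C)nn1Cc1cc(Cl)ccc1OCc1ccccc1` share the core. In this assay compound 2 gives > 3.7, again a limit. In this assay compound 3 gives > 3.7, also a limit. The measured steps are therefore a step that the two limits leave unreadable from compound 1 to compound 2, a step that the two limits leave unreadable from compound 1 to compound 3 and a step that the two limits leave unreadable from compound 2 to compound 3; none has a readable size, because of the limit of > 3.7 in this assay, at which 3 of the 3 values shown sit.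

Compound 4 `Cc1cc(NC(=O)CC2CCCCC2)nn1Cc1cc(Cl)ccc1OCc1ccccc1` is not yet measured. The change is ((cyclohexylmethyl)carbonyl)amino in place of phenylcarbamoyl on an aromatic carbon. The step from compound 1 to compound 3 is the nearest comparison, an amide-type group on the same aromatic carbon, but its size is not readable. No direction or size beyond the scatter can be read for this assay from these data; the expectation is that compound 4 sits at the limit as well. The estimate for compound 4 in this assay is 4.5 (range 3.7 to 5.5), which means an expected step that the limit leaves unreadable from compound 1 to compound 4.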

Compound 4, distribution coefficient: 3.2
Beside the measured number, compound 4's estimate is 1.30 log units above it; measured number outside the range, below it.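

In this assay, going by these compounds alone, compound 4 gives the first readable number, and the change at this aromatic carbon now has a direction: a number at least 0.50 log units lower from compound 1 to compound 4 (beyond the scatter), and likewise a number at least 0.50 log units lower from compound 2 to compound 4 (beyond the scatter). With the amide-type nitrogen held on the ring, changing only the group on the carbonyl carbon, cyclohexylmethyl in place of isopropyl, also moves the read-out: a number at least 0.50 log units lower from compound 3 to compound 4 (beyond the scatter). The steps among compound 1, compound 2 and compound 3 cannot be read, and the three new steps give only a minimum size, because of one shared limit: the limit of > 3.7 in this assay, at which 3 of the 4 values shown sit.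

Going by these compounds, the full size of each step remains open, as does which part of the cyclohexylmethyl group goes with the lower number. Also open, on these data alone, is where this assay would place a phenylmethyl group, a longer chain or an added amine on the carbonyl carbon.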